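The compounds below may be only part of what the source reports. "The series", "measured", "known", "first", "only" and "open" are said of these compounds alone.

Compound 1, with the structure `COC(=O)c1ccc(NCc2cncn2Cc2ccccc2)cc1-c1ccccc1`, was tested in a toxicity assay on NIH3T3 cells (Mus musculus) for cytotoxicity, read by resazurin assay; on this read-out lower numbers stand for an effect already at smaller amounts and higher numbers for an effect only at larger amounts of compound. In this assay compound 1 gives > 1000 nM, which is a limit of the assay and not a number. Going by the values given here, compound 2, with the structure `COC(=O)c1ccc(NCc2cncn2Cc2cccc(OC)c2)cc1-c1ccccc1`, has no single number to stand on: in this assay compound 2 is recorded as "not determined" (no result reported), and the only other value in view is the limit of > 1000 nM in this assay, at which 1 of the 2 values shown sits. Compound 3, with the structure `COC(=O)c1ccc(NCc2cncn2Cc2cccc(Cl)c2)cc1-c1ccccc1`, is not yet measured. It differs from compound 2 by chloro in place of methoxy on an aromatic carbon. Among the compounds with values here, with no measured step to lean on, the expectation for this assay is a step of no size beyond the usual scatter, in no particular direction, and most likely another limit rather than a number. For compound 3 the expected value in this assay is 3000 nM, with a range from 1000 nM to 10000 nM.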

Compound 3, half-maximal effective concentration: > 10000 nM
Compound 3: only a limit was reported (the forecaster's own chance of this, stated with the estimate: 70%); middle value at least 3.3-fold (0.52 log units) from the limit.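

In this assay, going by these compounds alone, compound 1 and compound 3 each carry only a limit and not a number, and compound 2 has no result, so no step among them can be read. The compounds shown leave open at what concentration any of them harms these cells.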